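The compounds below may be only part of what the source reports. "The series", "measured", "known", "first", "only" and "open" are said of these compounds alone.

Compound 2 `Cc1nn(C)c(Oc2ccc(Cl)cc2)c1/C=N\CCCCCCOc1cc2oc(=O)cc(C)c2cc1Cl` holds the only numbered result in a functional assay on U-87MG ATCC cells for antiproliferative activity against U-87 MG (Homo sapiens), read by MTT assay, with a stated time of 72 h; on this read-out lower numbers stand for stronger inhibition and higher numbers for weaker inhibition: compound 2 gives 3850 nM. Compound 1 `Cc1nn(C)c(Oc2ccc(F)c(F)c2)c1/C=N\CCCCCCOc1cc2oc(=O)cc(C)c2cc1Cl` reaches only a limit in this assay, > 25000 nM, namely (the limit of > 25000 nM in this assay, at which 1 of the 2 values shown sits). Among the measured compounds shown here, the single step seen, an at least 6.4-fold lower number from compound 1 to compound 2 (0.81 log units; beyond the scatter), comes from changing the aryl group on the oxygen. Compound 3 `Cc1nn(C)c(Oc2ccccc2Br)c1/C=N\CCCCCCOc1cc2oc(=O)cc(C)c2cc1Cl` differs from compound 2 by 2-bromophenyl in place of 4-chlorophenyl on an oxygen on an aromatic ring. That one step bears on this change yet does not cover it, so the expectation is uncertain. The estimate for compound 3 in this assay is 6000 nM, between 1500 nM and 25000 nM. That estimate means an expected step of a 1.6-fold higher number from compound 2 to compound 3 (0.19 log units; within the scatter), within the scatter.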

Compound 3, half-maximal inhibitory concentration: 21800 nM
Compound 3: middle estimate off by 3.6-fold (0.56 log units), on the low side, and the stated range covers the measured number.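

In this assay, replacing 4-chlorophenyl with 2-bromophenyl on this oxygen is not a neutral change: the result is a 5.7-fold higher number from compound 2 to compound 3 (0.75 log units; beyond the scatter). Compound 2 is now the strongest of the three, with its steps to both others beyond the scatter. The remaining step, an at least 1.1-fold lower number from compound 1 to compound 3 (0.05 log units; that floor lies within the scatter), cannot be read as a real difference, as it rests on a limit: the limit of > 25000 nM in this assay, at which 1 of the 3 values shown sits.

The halogen and its place change together in this step, so the compounds shown leave open which one matters; 2-chlorophenyl or 4-bromophenyl would separate them. Going by these compounds, how an unsubstituted phenyl or 4-methoxyphenyl on this oxygen would read also remains open.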